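A few compounds are considered here, and "the series" means these few. Any claim that something is new, unique, unknown or untested is made for them only; others in the source may bear on it.

Compound 1 `N#CC1=C(N)N(c2ccc(S(N)(=O)=O)cc2)C2=C(CCCC2)C1c1ccccc1O` gives 100% in a functional assay on Ehrlich cells (Mus musculus) for cytotoxicity, read by trypan blue exclusion, with a stated time of 2 h, tested at 100 ug/mL (a higher number here means a stronger effect of the compound at the concentration tested, a lower number a weaker effect), and compound 2 `N#CC1=C(N)N(c2ccc(S(N)(=O)=O)cc2)C2=C(CCCC2)C1/C=C/c1ccccc1` gives 70%. Among the measured compounds shown here, compound 2 thus stands lowest of the two numbers, with compound 1 as its only neighbour; the step of a number 30 percentage points lower from compound 1 to compound 2 (beyond the scatter) was modest. Compound 3 `N#CC1=C(N)N(c2ccc(S(N)(=O)=O)cc2)C2=C(CCCC2)C1c1ccc([N+](=O)[O-])cc1` differs from compound 2 by 4-nitrophenyl in place of 2-phenylethenyl on a saturated ring carbon. For the measured compounds named here, only that one measured step bears on this change, and it runs the other way. Since compound 1 also carries a substituted phenyl on a saturated ring carbon, compound 3 is expected to move back upward in this assay by a number 15 percentage points higher from compound 2 to compound 3 (beyond the scatter). Compound 3 is therefore estimated at 85%, between 60% and 100%.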

Compound 3, a percentage reported as activity, at one concentration (the size of the read-out at that concentration, not a potency): 20%
Compound 3: the middle estimate sits 65 percentage points above what was measured; the measured number lies below the stated range.
By their numbers in this assay, from the lowest: compound 3; then compound 2; then compound 1.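

In this assay a substituted phenyl on this saturated ring carbon does not by itself hold the effect up: the change to 4-nitrophenyl gives a number 80 percentage points lower from compound 1 to compound 3 (beyond the scatter) and so separates two phenyl-bearing compounds widely. The same change gives a number 50 percentage points lower from compound 2 to compound 3 (beyond the scatter) and so places 4-nitrophenyl under 2-phenylethenyl, leaving compound 3 lowest of the three. No measurement at hand accounts for this drop.

Still open, as far as these compounds go, is whether the loss follows the nitro group or its place on the phenyl ring. A 2-nitrophenyl or a 4-hydroxyphenyl group on this carbon would tell these apart.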